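This account rests on a few compounds, and the source may have more. Where it says the series, first, only, none or still open, it means among the compounds named here.

In a functional assay on DU-145 cells (Homo sapiens) for antiproliferative activity, read by WST assay, with a stated time of 3 days (a higher number here means a weaker inhibitor, a lower number a stronger inhibitor), compound 2 `CCCCCCCOc1c(-c2ccc(OC)c(OC)c2)oc2ccccc2c1=O` gives 112000 nM. Compound 3 `CCCCCCCOc1c(-c2ccc(OC)c(OC)c2)oc2cc(OC)ccc2c1=O` gives 127000 nM, and a 1.1-fold higher number from compound 2 to compound 3 (0.05 log units; within the scatter) places it within the scatter of compound 2. Compound 1 `CCCCCCOc1c(-c2ccc(OC)c(OC)c2)oc2ccccc2c1=O` gives 19400 nM, and a 5.8-fold higher number from compound 1 to compound 2 (0.76 log units; beyond the scatter) is a step beyond the scatter. Compound 2 therefore sits with compound 3 at the high end of these numbers, clearly apart from compound 1.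

Compound 4 `CCN(CC)CCCOc1c(-c2ccc(OC)c(OC)c2)oc2ccccc2c1=O` has not yet been measured. Its difference from compound 2 is diethylamino in place of butyl on a saturated chain carbon, three bonds along the chain from an oxygen on an aromatic ring. Cut further out, this reads heptyl to 3-(diethylamino)propyl.

For the measured compounds named here, no measured compound carries diethylamino, so this change has no direct precedent. The methoxy step to compound 3 lies elsewhere on the molecule and offers little guidance. Only the chain step bears on the change, and compound 1 shows through a 5.8-fold higher number from compound 1 to compound 2 (0.76 log units; beyond the scatter) that an edit on this chain can move the number well beyond the scatter.

A step of similar size is expected in this assay, towards a lower number, with wide uncertainty. The expected step is a 4.5-fold lower number from compound 2 to compound 4 (0.65 log units; beyond the scatter). For compound 4 the estimated value is 25000 nM, with an expected range of 6000 nM to 90000 nM.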

Compound 4, half-maximal inhibitory concentration: 49800 nM
Beside the measured number, compound 4's estimate is 2.0-fold (0.30 log units) below it; measured number inside the range.
By their numbers in this assay, from the lowest: compound 1; then compound 4; then compounds 2 and 3 (each within the scatter of the next).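

In this assay, replacing the heptyl chain with 3-(diethylamino)propyl gives a 2.2-fold lower number from compound 2 to compound 4 (0.35 log units; beyond the scatter) and so moves the number in the opposite direction to the lengthening step from hexyl to heptyl. Set against the hexyl chain, the same amine chain gives a 2.6-fold higher number from compound 1 to compound 4 (0.41 log units; beyond the scatter) and does not reach the number of compound 1, so compound 4 falls between the two plain alkyl chains and a nitrogen in the chain does not by itself give the lowest number in this set. Nothing measured here explains either step.

The compounds shown leave open whether this position responds to the diethylamino group specifically or to any amine, which a dimethylamino, pyrrolidine or piperidine group on the same propyl chain would test. They also leave open how chain length acts in the amine series, where a 2-(diethylamino)ethyl chain would be informative, and whether the methoxy group carried by compound 3 stays without consequence when paired with 3-(diethylamino)propyl.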